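The compounds below may be only part of what the source reports. "The series", "measured", "known", "first", "only" and "open" are said of these compounds alone.

Measured compounds in a functional assay on HL-60 cells (Homo sapiens) for antiproliferative activity, with a stated time of 24 h; on this read-out lower numbers stand for stronger inhibition and higher numbers for weaker inhibition:
Compound 1 `Cc1ccccc1NC(=S)N1CCc2c(sc(NC(=O)c3ccccc3Cl)c2C(N)=O)C1` gives 22600 nM.
Compound 2 `COc1ccccc1NC(=S)N1CCc2c(sc(NC(=O)c3ccccc3Cl)c2C(N)=O)C1` gives 40900 nM.
Compound 3 `Cc1ccccc1NC(=S)N1CCc2c(sc(NC(=O)c3ccccc3C(F)(F)F)c2C(N)=O)C1` gives 25100 nM.

Compound 4 `COc1ccccc1NC(=S)N1CCc2c(sc(NC(=O)c3ccccc3C(F)(F)F)c2C(N)=O)C1` is not yet measured. It differs from compound 3 by methoxy in place of methyl on an aromatic carbon. The same change is made between compound 1 and compound 2, namely (methoxy in place of methyl on an aromatic carbon), where it gave a 1.8-fold higher number from compound 1 to compound 2 (0.26 log units; within the scatter). The two cores differ by trifluoromethyl in place of chloro on an aromatic carbon, and that change gave a 1.1-fold higher number from compound 1 to compound 3 (0.05 log units; within the scatter). Both recorded steps stay within the scatter, and all three measured values lie close together. For compound 4 the step is expected to be a 1.7-fold higher number from compound 3 to compound 4 (0.23 log units; within the scatter), an estimate that rests on a 1.8-fold higher number from compound 1 to compound 2 (0.26 log units; within the scatter). Compound 4 is therefore expected at about 43000 nM, with a likely range from 20000 nM to 95000 nM.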

Compound 4, half-maximal inhibitory concentration: > 50000 nM
Compound 4 gave a limit, no number (the forecaster's own chance of this, stated with the estimate: 10%); middle value at least 1.1-fold (0.06 log units) from the limit.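

Compound 4 gives > 50000 nM in this assay as a limit of the assay and not a number. Methoxy in place of methyl on the core of compound 3 reads as an at least 1.9-fold higher number from compound 3 to compound 4 (0.29 log units; that floor lies within the scatter) and this floor does not show whether the change carries over from one core to the other at the same size: the same change on two cores in this assay, a 1.8-fold higher number (0.26 log units; within the scatter) from compound 1 to compound 2 and an at least 1.9-fold higher number (0.29 log units; that floor lies within the scatter) from compound 3 to compound 4; the limit leaves it open whether they differ. Trifluoromethyl in place of chloro, now with methoxy present, reads as an at least 1.2-fold higher number from compound 2 to compound 4 (0.08 log units; that floor lies within the scatter) and is likewise bounded on one side only: the same change on two cores in this assay, a 1.1-fold higher number (0.05 log units; within the scatter) from compound 1 to compound 3 and an at least 1.2-fold higher number (0.08 log units; that floor lies within the scatter) from compound 2 to compound 4; the limit leaves it open whether they differ.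

From the compounds shown here alone, the true number for compound 4 remains open, and with it the size of both steps. Also open is how the series responds at these places to a group other than those shown, such as a fluoro, a nitrile or an amine.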